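A few compounds are considered here, and "the series" means these few. Any claim that something is new, unique, unknown or untested is made for them only; others in the source may bear on it.

Working notes on the series, all values from a functional assay on BV-2 cells (Mus musculus) for inhibition, read by Griess assay, with a stated time of 24 h; a higher number here means a weaker inhibitor, a lower number a stronger inhibitor:

- Compound 1 `COc1ccc(Br)cc1-c1cc(CO)on1`: > 200000 nM (a limit)
- Compound 2 `C=CCc1ccc(OC)c(-c2cc(COCc3ccccc3)on2)c1`: > 200000 nM (a limit)
- Compound 3 `C=CCn1ccc(-c2cc(Br)ccc2O)n1`: 112000 nM

Within the data shown here, compound 3 carries the only actual number so far, at 112000 nM. The rest of the evidence is the limit of > 200000 nM in this assay, at which 2 of the 3 values shown sit. That gives one number to work from, and it sits not far from that limit.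

The next compound is compound 4 `Oc1ccc(Br)cc1-c1ccn(-c2ccccc2)n1`, which has phenyl in place of allyl on an aromatic nitrogen. Among the measured compounds shown here, no measured pair differs in one place only, so the data give no direct size for this kind of change, and the expectation for it is weakly founded. Starting from compound 3 at 112000 nM, a modest move toward stronger inhibition in this assay is expected, not much beyond the usual scatter. A result at the limit remains a real possibility. The expected change is a 1.9-fold lower number from compound 3 to compound 4 (0.27 log units; within the scatter). For compound 4 the estimated value is 60000 nM, with an expected range of 15000 nM to 200000 nM.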

Compound 4, half-maximal inhibitory concentration: > 200000 nM
Compound 4: only a limit was reported (the forecaster's own chance of this, stated with the estimate: 25%); middle value at least 3.3-fold (0.52 log units) away from the limit.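

In this assay, replacing allyl with phenyl on the aromatic nitrogen gives the series its first step between compounds that differ in one place: an at least 1.7-fold higher number from compound 3 to compound 4 (0.25 log units; that floor lies within the scatter). Compound 4 gives > 200000 nM, which is a limit and not a number, so this step has a floor but no measured size, and that floor does not clear the usual scatter. Phenyl at this position therefore shows no gain in inhibition, compound 3 remains the only compound with an actual number, and the series rests mostly on the limit: the limit of > 200000 nM in this assay, at which 3 of the 4 values shown sit.

From the compounds shown here alone, how far compound 4 lies from compound 3 stays open, and a limit cannot settle whether the true step is small or large. Also open, going by these compounds, is how an amine, a carboxylic acid or a longer chain in place of allyl on this aromatic nitrogen would read out, and whether any group at this position can move the number clearly away from that of compound 3.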